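The source may hold more compounds than are shown below. What is called first, only, known or untested is meant among the compounds shown, and "the series" means these compounds.

Compound 1 `CC(=O)Nc1ccc(S(=O)(=O)Nc2cccc(-c3nc(-c4ccc(NC(=O)c5cccnc5)cc4Cl)no3)c2)cc1Cl` opens the series. In a functional assay on MDA-MB-231 cells (Homo sapiens) for antiproliferative activity, read by MTT assay, with a stated time of 72 h (a lower number here means a stronger inhibitor, a higher number a weaker inhibitor), compound 1 gives > 10000 nM, which is a limit of the assay and not a number. Among the measured compounds shown here, compound 2 `Cc1ccc(NC(=O)Nc2cccc(-c3nc(-c4ccc(NC(=O)c5cccnc5)cc4Cl)no3)c2)cc1` carries a urea in place of the sulfonamide of compound 1, and in this assay compound 2 gives 3500 nM, the only actual number among the values shown.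

Compound 3 `CC(=O)Nc1ccc(NC(=O)Nc2cccc(-c3nc(-c4ccc(NC(=O)c5cccnc5)cc4Cl)no3)c2)cc1` differs from compound 2 in one place: acetamido in place of methyl on an aromatic carbon. For the measured compounds named here, no measured pair in the set carries this change, so its size is open. The step expected from compound 2 to compound 3 is a 1.4-fold higher number from compound 2 to compound 3 (0.15 log units; within the scatter), toward weaker inhibition but of a size that may not clear the scatter. Compound 3 is therefore estimated at 5000 nM in this assay, in the range 1500 nM to 15000 nM. A limit is possible, since compound 1 sits at the limit of > 10000 nM in this assay, at which 1 of the 2 values shown sits.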

Compound 3, half-maximal inhibitory concentration: > 10000 nM
Compound 3: a limit, no number; the forecaster's own chance of this, stated with the estimate: 30%; middle value at least 2.0-fold (0.30 log units) from the limit.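

In this assay, 4-acetamidophenyl in place of 4-methylphenyl on the urea gives an at least 2.8-fold higher number from compound 2 to compound 3 (0.45 log units; beyond the scatter). This shows that the position para to a large group is sensitive to what it carries, and that this change does not keep the activity of the methyl compound. The value of compound 3 is a limit and not a number, so the step has a lower bound but no measured size: the limit of > 10000 nM in this assay, at which 2 of the 3 values shown sit.

Among the compounds shown here, only one change at this position can be read, and it does not separate the larger group from its added hydrogen-bond donor and acceptor. From the compounds shown here alone, how an amine, a methoxy group or a carboxylic acid at the same place would read stays open, as does whether any group improves on methyl.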